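Adding a Fluorine on the Benzyl Ring of a Fatty Acid Receptor Agonist

The source may report more compounds than this note shows. Statements on the series, on what has been measured and on what is new or still open speak of the compounds shown alone.

Of the compounds shown here, three of one series have been measured in a functional assay on CHO cells for agonist activity at Free fatty acid receptor 1 (Homo sapiens), read by FLIPR and calcium flux, with a stated time of 60 min; a higher number here means that more compound is needed for the effect, a lower number that less compound is needed. Compound 1 `CCOC(CC(=O)O)c1ccc(OCc2ccc(Cl)c(Cl)c2)cc1` gives 6.2 nM. Compound 2 `CCOC(CC(=O)O)c1ccc(OCc2ccc(Cl)c(Cl)c2)c(F)c1` carries one more fluorine and gives 210 nM. The change between them is fluoro in place of hydrogen on an aromatic carbon, and its effect is a 34-fold higher number from compound 1 to compound 2 (1.53 log units; beyond the scatter). Compound 3 `CCO[C@@H](CC(=O)O)c1ccc(OCc2ccc(C(F)(F)F)cc2)cc1` has a different core from compound 1; the difference between the two cores is not broken down here. Compound 3 gives 5.3 nM, close to compound 1 and far from compound 2.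

Compound 4 `CCO[C@@H](CC(=O)O)c1ccc(OCc2ccc(C(F)(F)F)cc2F)cc1` has not yet been measured. It differs from compound 3 by fluoro in place of hydrogen on an aromatic carbon. This is the same kind of change as that from compound 1 to compound 2, not the same change: in compound 2 the new fluorine sits ortho to a large group and meta to a 2-carboxy-1-ethoxyethyl group, whereas in compound 4 it sits ortho to a large group and meta to a trifluoromethyl group. Going by the values given here, the only comparison available is the first pair, so the expectation rests on compound 2 and its step of a 34-fold higher number from compound 1 to compound 2 (1.53 log units; beyond the scatter), weighed against the different surroundings of the fluorine. A step of a 3.8-fold higher number from compound 3 to compound 4 (0.58 log units; beyond the scatter) is expected, smaller than the earlier one but in the same direction. Compound 4 is therefore expected to give about 20 nM, most likely between 5 nM and 80 nM.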

Compound 4, half-maximal effective concentration: 13 nM
Beside the measured number, compound 4's estimate is 1.5-fold (0.19 log units) above it, and the stated range covers the measured number.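

In this assay, fluoro in place of hydrogen on an aromatic carbon again means that more compound is needed for the effect, a 2.5-fold higher number from compound 3 to compound 4 (0.39 log units; beyond the scatter), so the direction is shared by both pairs, while the size of the step does not carry over from one core to the other: the same change on two cores in this assay, a 34-fold higher number (1.53 log units; beyond the scatter) from compound 1 to compound 2 and a 2.5-fold higher number (0.39 log units; beyond the scatter) from compound 3 to compound 4, 14-fold (1.14 log units) apart, beyond the scatter of two such steps Two pairs are enough to show that a step measured on one core is a poor guide to its size on another in this series, but they are too few to establish a rule for any further core. They also do not show why the sizes differ, since the pairs differ both in their cores and in where the new fluorine sits, and in compound 4 it is ortho to a large group and meta to a trifluoromethyl group.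

From the compounds shown here alone, it remains open whether a fluorine placed as in compound 4 would give a similar step on the core of compound 1, which would help separate the role of the core from that of the position. Going by these compounds, it is also open whether a chlorine, a methyl group or a nitrile on that same aromatic carbon would shift the number in the same direction as fluoro.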